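This account rests on a few compounds, and the source may have more. Where it says the series, first, only, none or still open, it means among the compounds named here.

In a functional assay on MIA cells (Homo sapiens) for cytotoxicity, read by MTT assay, with a stated time of 72 h (on this read-out higher numbers stand for weaker inhibition of growth and lower numbers for stronger inhibition of growth), compound 1 (`N#C/C(=C/c1ccc(Cl)cc1)C(=O)c1ccc[nH]1`) gives 59000 nM. Compound 2 (`N#C/C(=C/c1ccc([N+](=O)[O-])cc1)C(=O)c1ccc[nH]1`) stands at < 10000 nM, a limit of the assay and not a number. Compound 3 (`COc1ccc(/C=C(/C#N)C(=O)c2ccc[nH]2)cc1`) carries methoxy in place of nitro on an aromatic carbon, para to a large group: methoxy in place of nitro on an aromatic carbon. For the measured compounds named here, the one measured step bearing on this, an at least 5.9-fold lower number from compound 1 to compound 2 (0.77 log units; beyond the scatter), brought in nitro in place of chloro, so losing nitro is expected to give a higher number in this assay, by a modest step beyond the scatter. The expected change is an at least 2.5-fold higher number from compound 2 to compound 3 (0.39 log units; beyond the scatter). For compound 3 the estimated value is 25000 nM, within an expected range of 5000 nM to 100000 nM.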

Compound 3, concentration for 50% growth inhibition: < 10000 nM
Compound 3: no number, only a limit; the forecaster's own chance of this, stated with the estimate: 25%; middle value at least 2.5-fold (0.39 log units) away from the limit.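

For the compounds shown here, at this position, para to a large group, methoxy in place of chloro gives in this assay an at least 5.9-fold lower number from compound 1 to compound 3 (0.77 log units; beyond the scatter), so nitro is not the only group here that departs from chloro. Compound 3 gives < 10000 nM, a limit of the assay and not a number. The step from compound 2 to compound 3 cannot be read, because both share one limit: the limit of < 10000 nM in this assay, at which 2 of the 3 values shown sit.

As far as these compounds go, how far the true values of compound 2 and compound 3 lie from that limit stays open. Also open, from the compounds shown here alone, is whether an amine or a carboxylic acid at this position would give a lower number than compound 1.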